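The source may report more compounds than this note shows. Statements on the series, on what has been measured and on what is new or still open speak of the compounds shown alone.

Measured compounds:
compound 1 `COc1cc(-n2cnc3ccc(-c4ccc(C(F)(F)F)cc4)cc32)cc(OC)c1OC` — 760 nM
compound 2 `COc1ccccc1-c1ccc2ncn(-c3cc(OC)c(OC)c(OC)c3)c2c1` — 1750 nM
compound 3 `COc1cc(-n2cnc3ccc(-c4cccc([N+](=O)[O-])c4)cc32)cc(OC)c1OC` — 4560 nM

In a functional assay on MCF7 cells (Homo sapiens) for antiproliferative activity, read by MTT assay, with a stated time of 72 h (a lower number here means a stronger inhibitor, a higher number a weaker inhibitor), compound 3 gives the highest number of the three, with compound 2 nearest and compound 1 furthest from it. Compound 4 `COc1cc(-n2cnc3ccc(-c4ccc(C)cc4)cc32)cc(OC)c1OC` is not yet measured; it differs from compound 3 in one place: 4-methylphenyl in place of 3-nitrophenyl on an aromatic carbon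

Going by the values given here, two measured steps bear on this change, both ending at compound 3. The step of a 6.0-fold higher number from compound 1 to compound 3 (0.78 log units; beyond the scatter) exchanged one substituted phenyl for the 3-nitrophenyl and raised the number, as did the step of a 2.6-fold higher number from compound 2 to compound 3 (0.42 log units; beyond the scatter). Among the compounds with values here, compound 4 reverses the 3-nitrophenyl for a 4-methylphenyl, a group for which no step is measured here, so its number is expected to fall back toward those of compound 1 and compound 2 rather than beyond them. Compound 4 is therefore expected to show a step of a 3.8-fold lower number from compound 3 to compound 4 (0.58 log units; beyond the scatter), toward a lower number. On that basis compound 4 is estimated at 1200 nM, within a range from 400 nM to 3600 nM.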

Compound 4, half-maximal inhibitory concentration: 110 nM
Estimate against measurement, compound 4: 11-fold (1.04 log units) above, and the stated range ends above it.
By their numbers in this assay, from the lowest: compound 4; then compound 1; then compound 2; then compound 3.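

In this assay, compound 4 gives the lowest number of the four, and the 4-methylphenyl group separates itself clearly from the other two groups at this position: a 41-fold lower number from compound 3 to compound 4 (1.62 log units; beyond the scatter) and a 16-fold lower number from compound 2 to compound 4 (1.20 log units; beyond the scatter). The sharpest new point is that the position responds strongly even when the ring keeps its substituent in the same place, since exchanging only trifluoromethyl for methyl gives a 6.9-fold lower number from compound 1 to compound 4 (0.84 log units; beyond the scatter). Nothing shown here accounts for these differences.

The compounds leave open whether an ethyl group, a methoxy group or an amine in place of that methyl would keep the low number. They also cannot separate the identity of a substituent from its place on the ring, as the 3-nitrophenyl and 2-methoxyphenyl groups differ from 4-methylphenyl in both.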